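The compounds below may be only part of what the source reports. "The series", "measured", "known", "first", "only" and "open" are said of these compounds alone.

Measured so far in a functional assay on HepG2 cells (Homo sapiens) for antiproliferative activity, read by fluorescence and resazurin assay, with a stated time of 48 h; on this read-out lower numbers stand for stronger inhibition and higher numbers for weaker inhibition:
Compound 1, `O=C(N/N=C/c1ccncc1)c1cc2cc(Br)ccc2oc1=O`, gives 4890 nM.
Compound 2, `CCOc1ccc2nc(Cl)c(/C=N/NC(=O)c3cc4cc(Br)ccc4oc3=O)cc2c1`, gives 29000 nM.
Compound 3, `O=C(N/N=C/c1cccnc1)c1cc2cc(Br)ccc2oc1=O`, gives 19000 nM.

Compound 3 stands second highest of the three numbers. Its nearest neighbour is compound 2, whose number lies within the usual scatter of that of compound 3, so the two cannot be told apart on these data. Within the data shown here, compound 1 sits furthest away: the single change from compound 1 to compound 3, pyridin-3-yl in place of pyridin-4-yl on a carbon with a double bond to nitrogen, brought a 3.9-fold higher number from compound 1 to compound 3 (0.59 log units; beyond the scatter).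

Compound 4, `O=C(N/N=C/c1cccnc1)c1cc2cc([N+](=O)[O-])ccc2oc1=O`, differs from compound 3 in one place: nitro in place of bromo on an aromatic carbon. Among the measured compounds shown here, no measured pair in this set shares that change; the only step with a single difference concerns the pyridine ring, not the substituent on the six-membered aromatic ring of carbon only within the fused system. There is therefore nothing here to set the direction or size of the coming step. In the absence of a precedent, the step from compound 3 to compound 4 is estimated to remain within the scatter, a 1.3-fold lower number from compound 3 to compound 4 (0.10 log units; within the scatter). Compound 4 is expected to give about 15000 nM, with a range from 5000 nM to 45000 nM that reflects this uncertainty.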

Compound 4, half-maximal inhibitory concentration: 17000 nM
For compound 4 the middle estimate is 1.1-fold (0.05 log units) below the measured one, within the range that was stated.
By their numbers in this assay, from the lowest: compound 1; then compounds 4, 3 and 2 (each within the scatter of the next).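

In this assay, among these compounds, the first change at this position, nitro in place of bromo on an aromatic carbon of the six-membered aromatic ring of carbon only, gives a 1.1-fold lower number from compound 3 to compound 4 (0.05 log units; within the scatter), so compound 3 and compound 4 cannot be told apart. Although one heavy atom gives way to three heavy atoms, and the group that enters carries two hydrogen-bond acceptors where the group that leaves carries none, this swap stays within the scatter, whereas the earlier change at the pyridine ring gave a 3.9-fold higher number from compound 1 to compound 3 (0.59 log units; beyond the scatter). No measurement is available here that bears on this result.

The compounds shown leave open whether nitro in place of bromo would also stay within the scatter when paired with the pyridin-4-yl group of compound 1, since one step with a pyridin-3-yl group cannot show whether the result carries over to another pyridine attachment. Among the compounds shown here, they also leave open what an amine, a carboxylic acid or a longer chain on this same aromatic carbon would do to the number, so the tolerance seen here rests on only two groups.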